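This account rests on a few compounds, and the source may have more. Where it says the series, first, only, none or still open, it means among the compounds named here.

Working notes on the series, read in a functional assay on MCF7 cells (Homo sapiens) for antiproliferative activity; on this read-out higher numbers stand for weaker inhibition and lower numbers for stronger inhibition. Among the compounds with values here, compound 1 `CC(=O)Oc1ccc(C(=O)Nc2cc3ccc(OCC4CCCN(C)C4)c(C)c3oc2=O)cc1CC=C(C)C` gives 1650 nM and compound 2 `CC(=O)Oc1ccc(C(=O)Nc2cc3ccc(OCC4CCN(C)C4)c(C)c3oc2=O)cc1CC=C(C)C` gives 1880 nM, so compound 2 sits within the scatter of compound 1, the only other measured compound. Next is compound 3 `CC(=O)Oc1ccc(C(=O)Nc2cc3ccc(OCCC4CCCCN4)c(C)c3oc2=O)cc1CC=C(C)C`, with the change ((piperidin-2-yl)methyl in place of 1-methylpyrrolidin-3-yl on a saturated chain carbon bound to an oxygen on an aromatic ring). In words, this is (piperidin-2-yl)methyl in place of 1-methylpyrrolidin-3-yl on a saturated chain carbon bound to an oxygen on an aromatic ring. Within the data shown here, one measured step bears on it: a 1.1-fold higher number from compound 1 to compound 2 (0.06 log units; within the scatter), a swap of the ring at the same place. Among the measured compounds shown here, no measured compound carries the entering group, so this evidence is thin, and no direction can be drawn from it. The estimated move is a 1.3-fold lower number from compound 2 to compound 3 (0.10 log units; within the scatter), with nothing beyond the scatter expected. For compound 3 the expected value is 1500 nM, with an estimated range of 600 nM to 3800 nM.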

Compound 3, half-maximal inhibitory concentration: 710 nM
Beside the measured number, compound 3's estimate is 2.1-fold (0.32 log units) above it; the range from low to high includes it.
By their numbers in this assay, from the lowest: compound 3; then compounds 1 and 2 (each within the scatter of the next).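

In this assay this position, on a saturated chain carbon bound to an oxygen on an aromatic ring, now shows a change beyond the scatter: a 2.6-fold lower number from compound 2 to compound 3 (0.42 log units; beyond the scatter) and a 2.3-fold lower number from compound 1 to compound 3 (0.37 log units; beyond the scatter) both point to stronger inhibition, whereas the step between the two earlier compounds stayed within it. The (piperidin-2-yl)methyl group differs from 1-methylpyrrolidin-3-yl in ring size, heavy atoms and hydrogen-bond donors together, so the step cannot be assigned to any one of these differences. Nothing available accounts for the difference in the read-out.

The compounds shown leave open whether the ring hydrogen-bond donor or the longer 2-(piperidin-2-yl)ethyl chain goes with the stronger inhibition. A 2-(1-methylpiperidin-2-yl)ethyl group, or a 2-(pyrrolidin-2-yl)ethyl group, would separate these changes.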